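The source may hold more compounds than are shown below. What is called first, only, known or untested is meant among the compounds shown, and "the series" means these compounds.

Compound 1 `COc1ccc2c(c1)CC[C@@H](O)/C2=C/c1cc(OC)c(OC)c(OC)c1`: 2020 nM
Compound 2 `COc1ccc(/C=C2\c3cc(OC)c(OC)c(OC)c3CC[C@@H]2O)cc1N`: 740 nM

In a functional assay on SK-OV-3 cells (Homo sapiens) for inhibition, read by MTT assay (a lower number here means a stronger inhibitor, a higher number a weaker inhibitor), compound 2 gives 740 nM, the lower of the two numbers. Compound 1 gives 2020 nM, and this gap lies beyond the usual scatter. The two compounds differ in more than one place, so their gap cannot be tied to any single change.

Compound 3 `COc1ccc(/C=C2\c3cc(OC)c(OC)c(OC)c3CC[C@@H]2O)cc1C` keeps the core of compound 2 but has methyl in place of amino on an aromatic carbon. Going by the values given here, no measured pair shows this change, so the expectation is uncertain and is anchored on compound 2 at 740 nM. A moderate move towards a higher number in this assay, meaning a weaker inhibitor, is expected, and it may not clear the scatter. The estimated step is a 1.9-fold higher number from compound 2 to compound 3 (0.28 log units; within the scatter). For compound 3 the expected value is 1400 nM, with an estimated range of 500 nM to 4000 nM.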

Compound 3, half-maximal inhibitory concentration: 730 nM
Estimate against measurement, compound 3: 1.9-fold (0.28 log units) above; measured number inside the range.
By their numbers in this assay, from the lowest: compounds 3 and 2 (each within the scatter of the next); then compound 1.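

In this assay, methyl in place of amino on the aromatic carbon ortho to a methoxy group gives a 1.0-fold lower number from compound 2 to compound 3 (0.01 log units; within the scatter) and so leaves the number within the scatter. At this position, the change from 3-amino-4-methoxyphenyl to 4-methoxy-3-methylphenyl removes the hydrogen-bond donor and acceptor counted for amino, and the two compounds still cannot be told apart in this read-out. Nothing measured here offers an explanation for this result. What the compounds leave open is whether other groups at this position, such as hydroxyl, chlorine or a longer chain such as ethyl, would also stay within the scatter of compound 2 and compound 3. On these data alone, it also remains open whether the same step would hold if the neighbouring methoxy group gave way to ethoxy.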